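A few compounds are considered here, and "the series" means these few. Any claim that something is new, unique, unknown or untested is made for them only; others in the source may bear on it.

Measured so far in a functional assay on SF-268 cells (Homo sapiens) for cytotoxicity, read by sulforhodamine B assay, with a stated time of 48 h; on this read-out lower numbers stand for stronger inhibition of growth and higher numbers for weaker inhibition of growth:
compound 1 `Nc1nc(Cl)c2ncn(Cc3cccc(CCl)c3)c2n1`: 10200 nM
compound 2 `ClCc1ccc(Cn2cnc3ncnc(Cl)c32)cc1`: 3380 nM

Compound 2 stands at the lower of the two numbers in this assay; compound 1 gives the higher one, and the gap between them lies beyond the usual scatter. Within the data shown here, the two differ in more than one place, so their numbers show only that compound 2 inhibits growth more strongly; no single change can be read from them.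

Compound 3 `ClCc1ccc(Cn2cnc3nc(Cl)nc(Cl)c32)cc1` has not yet been measured in this assay. It differs from compound 2 in one place: chloro in place of hydrogen on an aromatic carbon. Among the measured compounds shown here, no step of this kind has been measured within the set, so the size of the effect is open. The expected step is a 1.4-fold lower number from compound 2 to compound 3 (0.13 log units; within the scatter), small and likely within the scatter. For compound 3 the estimate in this assay is 2500 nM, with a range from 800 nM to 8000 nM.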

Compound 3, concentration for total growth inhibition: 3980 nM
Beside the measured number, compound 3's estimate is 1.6-fold (0.20 log units) below it, within the range that was stated.
By their numbers in this assay, from the lowest: compounds 2 and 3 (each within the scatter of the next); then compound 1.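

In this assay, among these compounds, the first step that differs in one place is chloro in place of hydrogen on an aromatic carbon, between two ring nitrogen atoms: a 1.2-fold higher number from compound 2 to compound 3 (0.07 log units; within the scatter). The numbers of compound 2 and compound 3 cannot be told apart, so this position carries a chloro group with no measurable cost or gain in growth inhibition, at least on this one step. No measurement at hand explains this result.

The compounds shown leave open how a methoxy group or a nitrile would read at this position, as a single chloro step says little about groups of other kinds. Also open, as far as these compounds go, is what the chloromethyl group contributes to growth inhibition, which a comparison with a hydroxymethyl group in its place could show.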